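A Cyclobutyl Swap on the Compound 1 Scaffold

The source may hold more compounds than are shown below. What is called first, only, known or untested is meant among the compounds shown, and "the series" means these compounds.

Compound 1 `N#Cc1cnc(NCc2cnccc2C(F)(F)F)cc1N[C@H]1C[C@H](O)C1`: 900 nM
Compound 2 `N#Cc1cnc(NCc2cncnc2OCC(F)F)cc1N[C@H]1CC[C@@H](O)CC1`: 90 nM
Compound 3 `CC1(C)[C@H](O)C[C@@H]1Nc1nc(NCc2cnccc2C(F)(F)F)ncc1C#N`: 300 nM

These three compounds were tested in an assay on isolated protein for inhibition of protein kinase C theta type (Homo sapiens), read by TR-FRET, with a stated time of 2 h; on this read-out higher numbers stand for weaker inhibition and lower numbers for stronger inhibition. Compound 1 has the highest number of the three, so it is the weakest inhibitor here; compound 3 sits nearest to it and compound 2 furthest, both with differences beyond the usual scatter. Compound 4 `CC1(C)[C@@H](Nc2cc(NCc3cnccc3C(F)(F)F)ncc2C#N)C[C@H]1C(N)=O` is not yet measured. It differs from compound 1 in one place: 3-carbamoyl-2,2-dimethylcyclobutyl in place of 3-hydroxycyclobutyl on a nitrogen on an aromatic ring. Among the measured compounds shown here, no measured pair shows this exact change, so its effect is not known; compound 3 carries a related dimethyl-bearing ring on a different shared core and gives a lower number than compound 1. For compound 4 the expected step of a 2.3-fold lower number from compound 1 to compound 4 (0.35 log units; beyond the scatter) is modest, toward stronger inhibition, near the edge of the scatter. The estimate for compound 4 in this assay is 400 nM, in the range 100 nM to 1500 nM.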

Compound 4, half-maximal inhibitory concentration: 140 nM
Compound 4: the middle estimate sits 2.9-fold (0.46 log units) above what was measured; the measured number falls inside the stated range.
By their numbers in this assay, from the lowest: compounds 2 and 4 (each within the scatter of the next); then compound 3; then compound 1.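

At the nitrogen on the aromatic ring, in this assay, 3-carbamoyl-2,2-dimethylcyclobutyl in place of 3-hydroxycyclobutyl gives a 6.4-fold lower number from compound 1 to compound 4 (0.81 log units; beyond the scatter) and so a clear gain beyond the scatter. This position therefore accepts a larger group with no hydroxyl, and inhibition gets stronger rather than being lost. The compounds shown leave open how much of the step belongs to the carbamoyl and how much to the two methyl groups, and how a carboxylic acid would read in the carbamoyl's place. No measurement offered here explains the step.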